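Propyl to 2-chloroethyl on the shared core

A few compounds are considered here, and "the series" means these few. Any claim that something is new, unique, unknown or untested is made for them only; others in the source may bear on it.

In a functional assay on COLO 205 cells (Homo sapiens) for antiproliferative activity, read by MTT assay (on this read-out lower numbers stand for stronger inhibition and higher numbers for weaker inhibition), compound 1 (`COC(=O)N1CCCc2cc(S(=O)(=O)N3CC(c4ccccc4)NC3=O)ccc21`) gives 4020 nM, and compound 2 (`CCCOC(=O)N1CCCc2cc(S(=O)(=O)N3CC(c4ccccc4)NC3=O)ccc21`) gives 1420 nM, the lower of the two numbers. Compound 3 (`O=C(OCCCl)N1CCCc2cc(S(=O)(=O)N3CC(c4ccccc4)NC3=O)ccc21`) carries chloro in place of methyl on a saturated chain carbon, two bonds along the chain from an oxygen next to a carbonyl group. Among the compounds with values here, the only measured step, a 2.8-fold lower number from compound 1 to compound 2 (0.45 log units; beyond the scatter), is modest and bears only indirectly, since it adds ethyl and no measured compound carries chloro. The expected change, a 1.2-fold higher number from compound 2 to compound 3 (0.08 log units; within the scatter), is therefore a slightly higher number that stays within the scatter. For compound 3 the estimated value is 1700 nM, with an expected range from 700 nM to 4200 nM.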

Compound 3, half-maximal inhibitory concentration: 2820 nM
Compound 3: the middle estimate sits 1.7-fold (0.22 log units) below what was measured; the measured number falls inside the stated range.
By their numbers in this assay, from the lowest: compounds 2, 3 and 1 (each within the scatter of the next, the first and the last beyond it).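

In this assay the change from propyl to 2-chloroethyl gives a 2.0-fold higher number from compound 2 to compound 3 (0.30 log units; within the scatter) while chloromethyl in place of hydrogen on a saturated chain carbon bound to an oxygen next to a carbonyl group gives a 1.4-fold lower number from compound 1 to compound 3 (0.15 log units; within the scatter) and neither step leaves the scatter. Compound 3 therefore cannot be told apart from compound 2 or from compound 1, although those two lie beyond the scatter of each other. No measurement at hand offers an explanation for this result. The compounds shown leave open how an amine, a carboxylic acid or a longer chain would read at this place.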